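The source may report more compounds than this note shows. Statements on the series, on what has been measured and on what is new or still open speak of the compounds shown alone.

Compound 3 `COc1ccc2c(c1)NC(=O)CN2c1nc(COCCCC(=O)NO)nc2ccccc12` gives 550 nM in a functional assay on A549 cells (Homo sapiens) for inhibition, read by sulforhodamine B assay, with a stated time of 48 h (on this read-out higher numbers stand for weaker inhibition of growth and lower numbers for stronger inhibition of growth), the highest of the three numbers in hand. Compound 1 `COc1ccc2c(c1)NC(=O)CN2c1nc(Nc2ccc(C#N)cc2)nc2ccccc12` gives 6.17 nM and compound 2 `COc1ccc2c(c1)NC(=O)CN2c1nc(NCc2ccncc2)nc2ccccc12` gives 6.62 nM; a 1.1-fold higher number from compound 1 to compound 2 (0.03 log units; within the scatter). The two steps reaching compound 3 are large: an 89-fold higher number from compound 1 to compound 3 (1.95 log units; beyond the scatter) and an 83-fold higher number from compound 2 to compound 3 (1.92 log units; beyond the scatter). Compound 4 `COc1ccc2c(c1)NC(=O)CN2c1nc(N2CC(OC)C2)nc2ccccc12` carries 3-methoxyazetidin-1-yl in place of (3-(hydroxycarbamoyl)propoxy)methyl on an aromatic carbon. Both prior steps show that exchanging the (3-(hydroxycarbamoyl)propoxy)methyl group for a nitrogen-linked substituent at this position goes with a much lower number, so a large step downward is expected for compound 4, as an 18-fold lower number from compound 3 to compound 4 (1.26 log units; beyond the scatter). Since compound 4 has no aryl or pyridinylmethyl amine, as compounds 1 and 2 do, the expected value for compound 4 is 30 nM, within 6 nM to 200 nM.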

Compound 4, concentration for 50% growth inhibition: 17.5 nM
Beside the measured number, compound 4's estimate is 1.7-fold (0.23 log units) above it; the measured number falls inside the stated range.
By their numbers in this assay, from the lowest: compounds 1 and 2 (each within the scatter of the next); then compound 4; then compound 3.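

At this position, between two ring nitrogen atoms, a four-membered non-aromatic ring attached through its nitrogen, with no hydrogen-bond donor, brings a large drop in this assay, with a 31-fold lower number from compound 3 to compound 4 (1.50 log units; beyond the scatter). A low number here therefore does not require an aryl or pyridinylmethyl amine, though a modest gap remains, with a 2.6-fold higher number from compound 2 to compound 4 (0.42 log units; beyond the scatter) and a 2.8-fold higher number from compound 1 to compound 4 (0.45 log units; beyond the scatter). No measurement in hand accounts for these steps.

Open, as far as these compounds go, is whether the methoxy group contributes, which an unsubstituted azetidine would test. Also open, from the compounds shown here alone, is how a larger ring, such as morpholine or piperazine, compares at this position.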